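The source may hold more compounds than are shown below. What is called first, only, known or untested is meant among the compounds shown, and "the series" means these compounds.

Compound 1, `CC(c1ccc(-c2ccccc2)c(F)c1)c1nnc2n1N=C(c1ccc(Cl)cc1Cl)CS2`, gives 8600 nM.
Compound 2, `CC(C)Cc1ccc(C(C)c2nnc3n2N=C(c2ccc(OC(F)(F)F)cc2)CS3)cc1`, gives 9700 nM.
Compound 3, `CC(C)Cc1ccc(C(C)c2nnc3n2N=C(c2ccc(Br)cc2)CS3)cc1`, gives 6400 nM.

These numbers come from a functional assay on HepG2 cells (Homo sapiens) for inhibition, read by sulforhodamine B assay, with a stated time of 72 h; on this read-out higher numbers stand for weaker inhibition and lower numbers for stronger inhibition. Among the three measured compounds, compound 1 stands second highest; its nearest neighbour is compound 2 and its furthest is compound 3, and both gaps lie within the scatter, so the three compounds cannot be told apart on this read-out. Going by the values given here, only one pair of measured compounds differs in a single place, and that step was a 1.5-fold lower number from compound 2 to compound 3 (0.18 log units; within the scatter).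

The unmeasured compound 4, `CC(c1ccc(-c2ccccc2)c(F)c1)c1nnc2n1N=C(c1ccc([N+](=O)[O-])cc1)CS2`, is reached from compound 1 by the change (4-nitrophenyl in place of 2,4-dichlorophenyl on a carbon with a double bond to nitrogen). Among the compounds with values here, the single measured step concerns an exchange of one group for another on an aromatic carbon in a different pair of compounds, and it stayed within the scatter; it offers no direct guidance on replacing a 2,4-dichlorophenyl with a 4-nitrophenyl. Within the data shown here, nothing among the measured compounds suggests a step beyond the scatter, so the estimate rests on the value of compound 1 with a wide range. The step from compound 1 to compound 4 is therefore expected to be a 1.0-fold higher number from compound 1 to compound 4 (0.02 log units; within the scatter). Compound 4 is estimated at 9000 nM, within a range from 3000 nM to 27000 nM.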

Compound 4, half-maximal inhibitory concentration: 4300 nM
Compound 4: the middle estimate sits 2.1-fold (0.32 log units) above what was measured; measured number inside the range.
By their numbers in this assay, from the lowest: compounds 4, 3, 1 and 2 (each within the scatter of the next, the first and the last beyond it).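

In this assay, replacing the 2,4-dichlorophenyl group with 4-nitrophenyl on the carbon with a double bond to nitrogen gives a 2.0-fold lower number from compound 1 to compound 4 (0.30 log units; within the scatter), which stays within the scatter. This is the first step shown at this carbon in which the whole aromatic group changes, whereas the earlier step concerned only one substituent on an aromatic carbon. Here, two chlorine atoms leave and a group counted with two hydrogen-bond acceptors enters, yet the read-out does not separate the two compounds, so this carbon accepts a considerable change of substituents without a step beyond the scatter. Nothing measured here explains the size of this step.

The compounds shown leave open whether the two chlorines and the nitro group each matter, since both parts of the exchange happen in a single step and neither is seen alone. They also leave open whether an amine or a carboxylic acid on this aromatic ring would produce a step beyond the scatter, and whether the same exchange would behave alike on the core of compound 3.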